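The source may hold more compounds than are shown below. What is called first, only, known or untested is meant among the compounds shown, and "the series" means these compounds.

Working notes on the series, read in a functional assay on PANC-1 cells (Homo sapiens) for inhibition, read by MTT assay, with a stated time of 24 h; a higher number here means a weaker inhibitor, a lower number a stronger inhibitor. Compound 1 (`CC1(C)[C@H]2CC[C@]1(C)N(Cc1cn(-c3cccc(F)c3)nn1)C(=O)C2`) gives 220 nM, compound 2 (`CC1(C)[C@H]2CC[C@]1(C)N(Cc1cn(-c3ccc(C#N)cc3)nn1)C(=O)C2`) gives 250 nM and compound 3 (`CC1(C)[C@H]2CC[C@]1(C)N(Cc1cn(-c3cccc(C#N)c3)nn1)C(=O)C2`) gives 260 nM. Compound 3 cannot be separated from the other two: a 1.2-fold higher number from compound 1 to compound 3 (0.07 log units; within the scatter) and a 1.0-fold higher number from compound 2 to compound 3 (0.02 log units; within the scatter) both lie within the scatter.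

Compound 4 (`CC1(C)[C@H]2CC[C@]1(C)N(Cc1cn(-c3ccccc3F)nn1)C(=O)C2`) keeps the shared core and has 2-fluorophenyl in place of 3-cyanophenyl on an aromatic nitrogen. Among the measured compounds shown here, three measured steps bear on this change. Cyano in place of fluoro on an aromatic carbon is a 1.2-fold higher number from compound 1 to compound 3 (0.07 log units; within the scatter), the swap of the 3-cyanophenyl for the 4-cyanophenyl arrangement is covered by a 1.0-fold higher number from compound 2 to compound 3 (0.02 log units; within the scatter), and the remaining pair gives a 1.1-fold higher number from compound 1 to compound 2 (0.06 log units; within the scatter). All three stay within the scatter. The nearest measured comparison is compound 1, which also carries fluoro, at 220 nM. For the measured compounds named here, no measured compound carries 2-fluorophenyl, so that group remains untested here and the range is kept wide.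

No step beyond the scatter is expected in this assay, and the expected step is a 1.1-fold lower number from compound 3 to compound 4 (0.05 log units; within the scatter). Compound 4 is estimated at 230 nM, with an expected range of 110 nM to 500 nM.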

Compound 4, half-maximal inhibitory concentration: 150 nM
Beside the measured number, compound 4's estimate is 1.5-fold (0.19 log units) above it, within the range that was stated.
By their numbers in this assay, from the lowest: compounds 4, 1, 2 and 3 (each within the scatter of the next).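

The change to 2-fluorophenyl on an aromatic nitrogen of the five-membered ring stays within the scatter in this assay against all three earlier aryl groups: 3-cyanophenyl (a 1.7-fold lower number from compound 3 to compound 4 (0.24 log units; within the scatter)), 4-cyanophenyl (a 1.7-fold lower number from compound 2 to compound 4 (0.22 log units; within the scatter)) and 3-fluorophenyl (a 1.5-fold lower number from compound 1 to compound 4 (0.17 log units; within the scatter)). This extends the flat picture to a third arrangement on the phenyl ring, so these four compounds give no step beyond the scatter for either the placement of the fluoro or its exchange for a nitrile. No measured evidence on these compounds offers an explanation for the small differences.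

Still open, going by these compounds, is whether any group at this position moves the number beyond the scatter, for example an amine or a carboxylic acid on the phenyl ring, or a longer alkyl chain in place of the phenyl ring. Changes to the shared core also remain unaddressed by these compounds.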